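Trimming the Amide Side Chain to a Bare Amide

A few compounds are considered here, and "the series" means these few. Any claim that something is new, unique, unknown or untested is made for them only; others in the source may bear on it.

Measured so far in an assay on isolated protein for inhibition of Apoptosis regulator Bcl-2 (Homo sapiens), read by fluorescence polarization, with stated times of 5 min and 10 min; a higher number here means a weaker inhibitor, a lower number a stronger inhibitor:
- compound 1, `CC(C)=CCCC1=CC[C@H](C(=O)N(C)O)[C@@H](c2ccccc2)C1`: compound 1 gives 2100 nM
- compound 2, `COC(=O)c1ccc(NC(=O)[C@H]2CC=C(CCC=C(C)C)C[C@@H]2c2ccccc2)cc1`: compound 2 reaches only the limit of the assay, > 23000 nM
- compound 3, `COC(=O)CCNC(=O)[C@H]1CC=C(CCC=C(C)C)C[C@@H]1c1ccccc1`: compound 3 gives 3100 nM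

Compound 3 has the highest of the two numbers shown; its nearest neighbour is compound 1, and the step of a 1.5-fold higher number from compound 1 to compound 3 (0.17 log units; within the scatter) is within the scatter. For the measured compounds named here, the step of an at least 7.4-fold lower number from compound 2 to compound 3 (0.87 log units; beyond the scatter) is the one clear change, set against the limit (the limit of > 23000 nM in this assay, at which 1 of the 3 values shown sits).

Compound 4, `CC(C)=CCCC1=CC[C@H](C(N)=O)[C@@H](c2ccccc2)C1`, differs from compound 3 by hydrogen in place of 2-(methoxycarbonyl)ethyl on an amide-type nitrogen. Neither measured step removes the whole side chain: one swaps the group on the carbonyl carbon and stays within the scatter, the other swaps one chain for another. A loss of the chain is therefore expected to give a somewhat higher number in this assay, with wide uncertainty. Compound 4 is expected at 6000 nM, between 2000 nM and 25000 nM, a step of a 1.9-fold higher number from compound 3 to compound 4 (0.29 log units; within the scatter).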

Compound 4, inhibition constant: > 23000 nM
Compound 4 was reported as a limit (the forecaster's own chance of this, stated with the estimate: 25%); middle value at least 3.8-fold (0.58 log units) away from the limit.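

In this assay, taking the 2-(methoxycarbonyl)ethyl group off the amide-type nitrogen gives an at least 7.4-fold higher number from compound 3 to compound 4 (0.87 log units; beyond the scatter), so the bare carbamoyl does not keep the activity seen with this chain. Replacing the hydroxy(methyl)amino group on the carbonyl carbon with amino gives an at least 10-fold higher number from compound 1 to compound 4 (1.03 log units; beyond the scatter), so the plain amide falls short of both compound 1 and compound 3, which carry something more at this place. Compound 4 and compound 2 are both reported only as limits, so the step between them cannot be read: the limit of > 23000 nM in this assay, at which 2 of the 4 values shown sit.

Going by these compounds, what remains open is how much of the chain is needed, for instance whether a simple methyl or ethyl group on the nitrogen would be enough. A carboxylic acid in place of the methyl ester at the end of the chain would show whether the ester itself matters.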